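Three Aryl Ethers at the Limit, a Fourth Awaits

A few compounds are considered here, and "the series" means these few. Any claim that something is new, unique, unknown or untested is made for them only; others in the source may bear on it.

Compound 3, `O=C(O)c1csc([C@H]2CC[C@@H]3[C@@H](COc4ccc(F)cc4)[C@H](O)C[C@@H]3O2)n1`, carries a 4-fluorophenyl on an oxygen on a saturated carbon of the shared core. In an assay on HEK293 cells for agonist activity at prostaglandin E2 receptor EP2 subtype (Homo sapiens), read by a beta-galactosidase reporter and beta-arrestin recruitment, with a stated time of 90 min (on this read-out lower numbers stand for an effect already at smaller amounts and higher numbers for an effect only at larger amounts of compound), compound 3 gives only a limit of the assay, > 10000 nM. Compound 1, `O=C(O)c1csc([C@H]2CC[C@@H]3[C@@H](COc4ccccc4F)[C@H](O)C[C@@H]3O2)n1`, with a 2-fluorophenyl on that same oxygen, likewise returns a limit in this assay, > 10000 nM. Compound 2, `Cc1ccc(OC[C@@H]2[C@H]3CC[C@H](c4nc(C(=O)O)cs4)O[C@H]3C[C@H]2O)cc1`, bearing a 4-methylphenyl there, also gives a limit in this assay, > 10000 nM. The three steps among them, a step that the two limits leave unreadable from compound 1 to compound 2, a step that the two limits leave unreadable from compound 1 to compound 3 and a step that the two limits leave unreadable from compound 2 to compound 3, are therefore unreadable, as the limit of > 10000 nM in this assay, at which 3 of the 3 values shown sit, records. Compound 4, `O=C(O)c1csc([C@H]2CC[C@@H]3[C@@H](COc4ccccc4C(F)(F)F)[C@H](O)C[C@@H]3O2)n1`, has not yet been measured; its change from compound 3 is 2-(trifluoromethyl)phenyl in place of 4-fluorophenyl on an oxygen on a saturated carbon. For the measured compounds named here, no measured step bears readably on this exchange; every aryl ether so far sits at the same limit, and the numbers give no direction for a larger substituent at this oxygen. Going by the values given here, the author therefore expects no step that the numbers could show beyond the scatter, and estimates the move from compound 3 to compound 4 as a step that the limit leaves unreadable from compound 3 to compound 4. His estimate for compound 4 in this assay is 20000 nM, expected to lie between 3000 nM and 100000 nM, and most likely reported again only as a limit.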

Compound 4, half-maximal effective concentration: 11 nM
Compound 4: middle estimate off by 1800-fold (3.26 log units), on the high side; measured number below the stated range.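

The position on the oxygen on a saturated carbon, silent across the earlier aryl ethers, now proves able to move this assay strongly: with 2-(trifluoromethyl)phenyl in place of 4-fluorophenyl the result is an at least 900-fold lower number from compound 3 to compound 4 (2.95 log units; beyond the scatter), and with it in place of 4-methylphenyl the result is an at least 900-fold lower number from compound 2 to compound 4 (2.95 log units; beyond the scatter). The tightest comparison is trifluoromethyl in place of fluoro on an aromatic carbon, an at least 900-fold lower number from compound 1 to compound 4 (2.95 log units; beyond the scatter), so a change in this single substituent separates a measured number from a limit, and the presence of fluorine alone on the aryl group does not bring a measured number. The steps among compound 1, compound 2 and compound 3 still cannot be read, and each new step is only a bound, since one end of it is a limit and not a number: the limit of > 10000 nM in this assay, at which 3 of the 4 values shown sit.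

The compounds shown leave open whether the effect belongs to trifluoromethyl itself or would also appear with a 2-chlorophenyl, 2-methylphenyl or 2-methoxyphenyl on the same oxygen. They also do not tell how a 4-(trifluoromethyl)phenyl or 3-(trifluoromethyl)phenyl would compare with compound 4.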